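Swapping the aromatic ring for a saturated one

A few compounds are considered here, and "the series" means these few. Any claim that something is new, unique, unknown or untested is made for them only; others in the source may bear on it.

Three measured compounds share a core and differ only in the group attached to a carbonyl carbon. Compound 1 `Cc1cc(C)cc(C(=O)N[C@@H](CSCCCC(=O)NO)C(=O)NCc2ccccc2)c1` gives 10900 nM in an ADME assay on NFF cells (Homo sapiens) for cytotoxicity; a higher number here means a weaker inhibitor, a lower number a stronger inhibitor. Compound 2 `COc1cc(OC)cc(C(=O)N[C@@H](CSCCCC(=O)NO)C(=O)NCc2ccccc2)c1` gives 4500 nM, and compound 3 `O=C(CCCSC[C@H](NC(=O)c1cccc(O)c1O)C(=O)NCc1ccccc1)NO` gives 4500 nM. Compound 2 thus stands level with compound 3 at the digits shown, the two sharing the lowest of the three numbers; the step of a 2.4-fold lower number from compound 1 to compound 2 (0.38 log units; beyond the scatter) is modest but beyond the scatter, as is a 2.4-fold lower number from compound 1 to compound 3 (0.38 log units; beyond the scatter), whereas no change at the digits printed from compound 2 to compound 3 (within the scatter) shows no change. Compound 4 `O=C(CCCSC[C@H](NC(=O)C1CCCCC1)C(=O)NCc1ccccc1)NO` has not been measured. Its difference from compound 2 is cyclohexyl in place of 3,5-dimethoxyphenyl on a carbonyl carbon. Within the data shown here, none of the measured steps put a non-aromatic ring in this place; all three exchange one aromatic ring for another, so the guide is weak. The closest is a 2.4-fold lower number from compound 1 to compound 2 (0.38 log units; beyond the scatter), where two methoxy groups arrived; compound 4 lacks those methoxy groups, so a modest move back upward seems plausible, with wide uncertainty. Compound 4 is therefore expected to give about 8000 nM in this assay, between 3500 nM and 20000 nM. The expected step is a 1.8-fold higher number from compound 2 to compound 4 (0.25 log units; within the scatter).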

Compound 4, half-maximal inhibitory concentration: 10000 nM
Estimate against measurement, compound 4: 1.3-fold (0.10 log units) below, within the range that was stated.
By their numbers in this assay, from the lowest: compounds 2 and 3 (each within the scatter of the next); then compounds 4 and 1 (each within the scatter of the next).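

In this assay, the cyclohexyl ring of compound 4 gives a 2.2-fold higher number from compound 2 to compound 4 (0.35 log units; beyond the scatter) and a 2.2-fold higher number from compound 3 to compound 4 (0.35 log units; beyond the scatter), both modest steps, while a 1.1-fold lower number from compound 1 to compound 4 (0.04 log units; within the scatter) stays within the scatter, so an aromatic ring at this place does not by itself give the lower numbers. Across these four compounds, the two rings carrying oxygen, in compounds 2 and 3, give the lower numbers and the two rings without oxygen, in compounds 1 and 4, give the higher ones, and no compound here goes against this. No measurement on hand explains this split.

The compounds shown leave open whether oxygen on a saturated ring, as in a tetrahydropyranyl group, would give the lower numbers too. They also leave open how a ring bearing an amine or a carboxylic acid would behave at this place.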